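Anilino-biaryl series: pyrazole for pyridine on the aryl ring

The source may report more compounds than this note shows. Statements on the series, on what has been measured and on what is new or still open speak of the compounds shown alone.

Measured compounds:
- compound 1, `CCN(c1ccc(C#N)c(Cl)c1)c1cc(-c2ccncc2)ccc1C`: 3580 nM
- compound 2, `Cc1noc(C)c1-c1cccc(Oc2ccc(C#N)c(C(F)(F)F)c2)c1`: "not determined" (no result reported)

Within the data shown here, compound 1 is the only member of the series with a number in a functional assay on PC-3 cells (Homo sapiens) for antiproliferative activity, read by CCK-8 assay, with a stated time of 6 days; on this read-out lower numbers stand for stronger inhibition and higher numbers for weaker inhibition; compound 2 was not taken through that assay, so no comparison between the two is possible and compound 1 stands alone as the sole reference point. Its value is a weak one on this read-out.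

Compound 3, `CCN(c1ccc(C#N)c(Cl)c1)c1cc(-c2c[nH]nc2C)ccc1C`, keeps the core of compound 1 and differs in a single position: 3-methyl-1H-pyrazol-4-yl in place of pyridin-4-yl on an aromatic carbon. The group that enters sits on an aromatic carbon of a six-membered aromatic ring of carbon only, meta to a large group and para to a methyl group, where the pyridin-4-yl of compound 1 stood.

Among the measured compounds shown here, no step between two measured compounds exists in this set, so nothing measured tells how a change at this position moves the number. The expectation is therefore anchored on compound 1 alone; the step of a 1.3-fold lower number from compound 1 to compound 3 (0.11 log units; within the scatter) is expected to stay within the usual scatter, with no clear direction. Compound 3 is estimated at 2800 nM, within the range 700 nM to 11000 nM.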

Compound 3, half-maximal inhibitory concentration: 9030 nM
The estimate for compound 3 lay 3.2-fold (0.51 log units) below the measured number; measured number inside the range.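

In this assay, among these compounds, the exchange of pyridin-4-yl for 3-methyl-1H-pyrazol-4-yl gives a 2.5-fold higher number from compound 1 to compound 3 (0.40 log units; beyond the scatter) and thus provides the first measured change at this aromatic carbon, meta to a large group and para to a methyl group. The number therefore responds to the group at this place, and the shift is towards weaker inhibition, even though the two groups match in heavy atoms and differ in ring size, hetero atoms and hydrogen-bond donors. Nothing available bears on which of these differences lies behind the step.

Among the compounds shown here, with only this pair, the effect of the five-membered ring cannot be separated from that of its methyl group, and an unsubstituted 1H-pyrazol-4-yl, a pyridin-3-yl or a plain phenyl at this place would be needed to tell them apart. Also open, as far as these compounds go, is whether any group here, such as an aminomethyl or a carboxylic acid on the ring, can improve on compound 1 at 3580 nM in this assay on this read-out.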